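From 4-methoxyphenyl to phenyl in compound 4

The source may report more compounds than this note shows. Statements on the series, on what has been measured and on what is new or still open speak of the compounds shown alone.

In a functional assay on MCF7 cells (Homo sapiens) for inhibition, read by MTT assay, with a stated time of 72 h (a lower number here means a stronger inhibitor, a higher number a weaker inhibitor), compound 1 (`COc1ccc(-c2nnc(SCCCN3CCN(c4nc5ccccc5o4)CC3)o2)cc1`) gives 52800 nM and compound 2 (`Fc1ccc(-c2nnc(SCCCN3CCN(c4nc5ccccc5o4)CC3)o2)cc1`) gives 52300 nM. Compound 3 (`COc1ccc(-c2nnc(SCCCN3CCN(c4nc5ccccc5s4)CC3)o2)cc1`) gives 171000 nM, the highest number of the three and beyond the scatter of the other two. Compound 4 (`c1ccc(-c2nnc(SCCCN3CCN(c4nc5ccccc5s4)CC3)o2)cc1`) has not yet been measured. It differs from compound 3 by hydrogen in place of methoxy on an aromatic carbon, para to a large group, which turns 4-methoxyphenyl to phenyl: hydrogen in place of methoxy on an aromatic carbon. For the measured compounds named here, no measured step makes exactly this change. The closest one puts fluoro in place of methoxy on an aromatic carbon and gave a 1.0-fold lower number from compound 1 to compound 2 (0.00 log units; within the scatter). The other measured step, a 3.2-fold higher number from compound 1 to compound 3 (0.51 log units; beyond the scatter), puts 1,3-benzothiazol-2-yl in place of 1,3-benzoxazol-2-yl and says little about the methoxy group. In this assay, the expected change is therefore none beyond the scatter, with an estimated 1.1-fold lower number from compound 3 to compound 4 (0.06 log units; within the scatter). Compound 4 is expected at about 150000 nM, with an estimated range of 75000 nM to 300000 nM.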

Compound 4, half-maximal inhibitory concentration: 76900 nM
Compound 4: middle estimate off by 2.0-fold (0.29 log units), on the high side; the measured number falls inside the stated range.
By their numbers in this assay, from the lowest: compounds 2, 1 and 4 (each within the scatter of the next); then compound 3.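

In this assay, replacing methoxy with hydrogen on this aromatic carbon moves the number beyond the scatter (a 2.2-fold lower number from compound 3 to compound 4 (0.35 log units; beyond the scatter)), so this position can matter. The earlier step at the same place, fluoro in place of methoxy with a 1,3-benzoxazol-2-yl group on the amine nitrogen, stayed within the scatter (a 1.0-fold lower number from compound 1 to compound 2 (0.00 log units; within the scatter)). These two steps differ both in the entering group and in the 1,3-benzothiazol-2-yl group shared by compound 3 and compound 4, and no evidence at hand accounts for the contrast.

From the compounds shown here alone, it remains open whether hydrogen would give the same step with the 1,3-benzoxazol-2-yl group, and whether fluoro would match hydrogen with the 1,3-benzothiazol-2-yl group. An amine, a carboxylic acid or a longer chain such as ethoxy at this place could show how far the number follows the group there.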